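The source may hold more compounds than are shown below. What is called first, only, known or untested is meant among the compounds shown, and "the series" means these compounds.

Measured compounds:
compound 1, `NC(=O)CN(CCC(c1ccccc1)c1ccccc1)C(=O)CN(CCC(c1ccccc1)c1ccccc1)C(=O)CNCC1CCCO1`, giving 2.27 uM
compound 2, `NC(=O)CN(CCC(c1ccccc1)c1ccccc1)C(=O)CNCCC(c1ccccc1)c1ccccc1`, giving 1.64 uM
compound 3, `O=C(CNCCC(c1ccccc1)c1ccccc1)NCCC(c1ccccc1)c1ccccc1`, giving 3.03 uM

In an ADME assay on HT-29 cells (Homo sapiens) for cytotoxicity, with a stated time of 72 h (a higher number here means a weaker inhibitor of growth, a lower number a stronger inhibitor of growth), compound 3 shows the highest of the three numbers, though its distances to compound 1 and to compound 2 both lie within the scatter. Compound 4, `O=C(CN(CCC(c1ccccc1)c1ccccc1)C(=O)CNCC1CCCO1)NCCC(c1ccccc1)c1ccccc1`, is the next step: ((((oxolan-2-yl)methyl)amino)methyl)carbonyl in place of hydrogen on an amine nitrogen. For the measured compounds named here, the one measured step that bears on this change runs the other way, a 1.4-fold lower number from compound 1 to compound 2 (0.14 log units; within the scatter), where the same group left the same kind of amine nitrogen. Reversed, it points to no movement beyond the scatter, if anything a slightly higher number. The step of a 1.8-fold higher number from compound 2 to compound 3 (0.27 log units; within the scatter) concerns a different position and adds little here. For compound 4 the expected result is 3.8 uM, in the range 1.6 uM to 9 uM. For compound 4 this means an expected step of a 1.3-fold higher number from compound 3 to compound 4 (0.10 log units; within the scatter).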

Compound 4, concentration for growth inhibition (reported as GI): 0.94 uM
For compound 4 the middle estimate is 4.0-fold (0.61 log units) above the measured one; measured number below the stated range.
By their numbers in this assay, from the lowest: compounds 4, 2, 1 and 3 (each within the scatter of the next, the first and the last beyond it).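

In this assay, ((((oxolan-2-yl)methyl)amino)methyl)carbonyl on this amine nitrogen brings a 3.2-fold lower number from compound 3 to compound 4 (0.51 log units; beyond the scatter), so the effect of this change depends on the core that carries it: the same change on two cores in this assay, a 1.4-fold lower number (0.14 log units; within the scatter) from compound 1 to compound 2 and a 3.2-fold higher number (0.51 log units; beyond the scatter) from compound 4 to compound 3, 4.5-fold (0.65 log units) apart, beyond the scatter of two such steps. Hydrogen in place of carbamoylmethyl on the amide-type nitrogen brings a 2.4-fold lower number from compound 1 to compound 4 (0.38 log units; beyond the scatter), and this change also depends on the core: the same change on two cores in this assay, a 1.8-fold higher number (0.27 log units; within the scatter) from compound 2 to compound 3 and a 2.4-fold lower number (0.38 log units; beyond the scatter) from compound 1 to compound 4, 4.5-fold (0.65 log units) apart, beyond the scatter of two such steps.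

The compounds shown leave open whether the oxolane ring itself matters to this lower number, or whether an open methoxyethyl chain on the same amino nitrogen would give a similar result. As far as these compounds go, a simple acetyl group on the amine nitrogen also remains untested here.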